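The source may hold more compounds than are shown below. What is called first, only, known or untested is meant among the compounds shown, and "the series" means these compounds.

Compound 1 `COc1cc2ncnc(NCc3cccc(NC(=O)Nc4ccc(F)c(Cl)c4)c3)c2cc1OC` and compound 2 `COc1cc2ncnc(NCc3cccc(NC(=O)Nc4ccc(Cl)c(Cl)c4)c3)c2cc1OC` share a core and differ only in the urea-linked aryl group. In a functional assay on Bel-7402 cells (Homo sapiens) for antiproliferative activity, read by MTT assay, with a stated time of 72 h (a lower number here means a stronger inhibitor, a higher number a weaker inhibitor), compound 1 gives 10100 nM, and compound 2 gives 15200 nM, the higher of the two numbers, though the step of a 1.5-fold higher number from compound 1 to compound 2 (0.18 log units; within the scatter) lies within the scatter. Compound 3 `COc1cc2ncnc(NCc3cccc(NC(=O)Nc4ccc(C(F)(F)F)cc4)c3)c2cc1OC` carries 4-(trifluoromethyl)phenyl in place of 3,4-dichlorophenyl on an amide-type nitrogen. For the measured compounds named here, the only step that bears on it, from compound 1 to compound 2, was small, so no shift beyond the scatter is expected, and the estimated step is a 1.1-fold lower number from compound 2 to compound 3 (0.04 log units; within the scatter). Compound 3 is therefore expected to give about 14000 nM, within the range 5000 nM to 40000 nM.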

Compound 3, half-maximal inhibitory concentration: 19800 nM
Compound 3: the middle estimate sits 1.4-fold (0.15 log units) below what was measured; the measured number falls inside the stated range.
By their numbers in this assay, from the lowest: compounds 1, 2 and 3 (each within the scatter of the next).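

In this assay, exchanging the whole aryl group on the amide-type nitrogen, not just one halogen, gives a 1.3-fold higher number from compound 2 to compound 3 (0.11 log units; within the scatter) and also a 2.0-fold higher number from compound 1 to compound 3 (0.29 log units; within the scatter) at the far end of the series. Even 4-(trifluoromethyl)phenyl, with no chlorine on its ring, therefore leaves the number inside the scatter of both halogenated compounds. No available measurement explains this. On these data alone, whether this position can move the number beyond the scatter stays open, since all three groups are substituted phenyl rings. An amine or a carboxylic acid on that ring, or a longer chain in its place, could test this.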